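This account rests on a few compounds, and the source may have more. Where it says the series, first, only, none or still open, it means among the compounds named here.

Working notes on the series, propylsulfonyl-piperidine amides of the dichlorobenzoyl type.

Compound 2 `CCCS(=O)(=O)N1CCC(CNC(=O)c2ccc(Cl)cc2Cl)(N2CCC2)CC1` gives the weaker of the two numbers in hand: in an assay on isolated protein for inhibition of sodium- and chloride-dependent glycine transporter 1 (Homo sapiens) (on this read-out higher numbers stand for weaker inhibition and lower numbers for stronger inhibition), compound 2 gives 38.1 nM. Going by the values given here, its only measured neighbour is compound 1 `CCCS(=O)(=O)N1CCC(CNC(=O)c2ccc(Cl)cc2Cl)(C2CCCCC2O)CC1`, which in this assay gives 2.8 nM; the one step between them, a 14-fold higher number from compound 1 to compound 2 (1.13 log units; beyond the scatter), shows that the group on this saturated ring carbon moves the read-out well beyond the scatter.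

Compound 3 `CCCS(=O)(=O)N1CCC(CNC(=O)c2ccc(Cl)cc2Cl)(CC2CC2)CC1` is the next entry at the same position, with cyclopropylmethyl in place of azetidin-1-yl on a saturated ring carbon. Among the compounds with values here, no measured step covers this particular exchange; the step from compound 1 to compound 2 is the only one that bears on it, and it establishes only that changes at this carbon can be large. The group entering compound 3 carries no acceptor, unlike the group it replaces, and it is a carbon-only ring of similar size. On this thin basis a modest move toward a lower number is expected in this assay, with wide uncertainty: compound 3 is estimated at 15 nM, in a range of 3 nM to 70 nM, which would correspond to an expected step of a 2.5-fold lower number from compound 2 to compound 3 (0.40 log units; beyond the scatter).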

Compound 3, half-maximal inhibitory concentration: 30 nM
Compound 3: the middle estimate sits 2.0-fold (0.30 log units) below what was measured; the measured number falls inside the stated range.
By their numbers in this assay, from the lowest: compound 1; then compounds 3 and 2 (each within the scatter of the next).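

At this saturated ring carbon, exchanging azetidin-1-yl for the carbon-only cyclopropylmethyl, which has no hydrogen-bond acceptor, gives a 1.3-fold lower number from compound 2 to compound 3 (0.10 log units; within the scatter) in this assay, so this exchange of two groups of equal heavy-atom count does not register in the read-out. The large difference from compound 1 now appears with a second group, an 11-fold higher number from compound 1 to compound 3 (1.03 log units; beyond the scatter), so it is not confined to azetidin-1-yl and separates 2-hydroxycyclohexyl from both smaller groups shown. No measurement on hand accounts for either step.

Still open, as far as these compounds go, is whether the lower number of compound 1 goes with the hydroxyl or with the cyclohexyl ring that carries it, a question that plain cyclohexyl and a small hydroxymethyl group at the same carbon would help to separate. Also open, from the compounds shown here alone, is whether open-chain groups at this carbon, such as dimethylamino or n-butyl, would read like compound 2 and compound 3 or move toward compound 1.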